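The source may report more compounds than this note shows. Statements on the series, on what has been measured and on what is new or still open speak of the compounds shown alone.

Measured in a functional assay on HEK239 cells (Homo sapiens) for inhibition, read by ELISA, with a stated time of 24 h; a higher number here means a weaker inhibitor of growth, a lower number a stronger inhibitor of growth:
Compound 1 `O=C(Cl)/C=C/c1ccccc1OC(=O)c1ccccc1`: > 100000 nM (a limit of the assay)
Compound 2 `CO/N=C/C=C/c1ccccc1OC(=O)c1ccccc1`: > 100000 nM (a limit of the assay)
Compound 3 `CN1CCN(C(=O)ONC(=O)/C=C/c2ccccc2OC(=O)c2ccccc2)CC1`: 89300 nM

Compound 3 is the only one of the three with an actual number. The other two carry only a limit, so the three cannot be put in a full order. Compound 4 `CC(=O)ONC(=O)/C=C/c1ccccc1OC(=O)c1ccccc1` has not been measured yet. It differs from compound 3 by a single change, (methyl in place of 4-methylpiperazin-1-yl on a carbonyl carbon). In words, methyl takes the place of 4-methylpiperazin-1-yl on a carbonyl carbon, so that (4-methylpiperazin-1-yl)carbonyl becomes acetyl.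

Going by the values given here, the only measured step is a step that the two limits leave unreadable from compound 1 to compound 2. Among the compounds with values here, it involves a different change and has no readable size, so no measured step bears directly on this one. What remains is the overall picture, (the limit of > 100000 nM in this assay, at which 2 of the 3 values shown sit). The expectation therefore rests on compound 3 with 89300 nM, and no step beyond the usual scatter is expected in this assay, in either direction. The expected size is a 1.1-fold lower number from compound 3 to compound 4 (0.05 log units; within the scatter). For compound 4 the estimated value is 80000 nM, with an expected range from 25000 nM to 100000 nM.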

Compound 4, concentration for 50% growth inhibition: 18600 nM
The estimate for compound 4 lay 4.3-fold (0.63 log units) above the measured number, and the stated range ends above it.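

In this assay, going by these compounds alone, the group on the carbonyl carbon proves to matter: methyl in place of 4-methylpiperazin-1-yl, which turns (4-methylpiperazin-1-yl)carbonyl into acetyl, gives a 4.8-fold lower number from compound 3 to compound 4 (0.68 log units; beyond the scatter), the first step of readable size and one that a much smaller group of a single carbon produces. Within the data shown here, the whole acetoxyamino group also stands apart from the groups found at the same place in the earlier compounds, with acetoxyamino in place of chloro giving an at least 5.3-fold lower number from compound 1 to compound 4 (0.73 log units; beyond the scatter), and the exchange at the double-bonded chain carbon giving an at least 5.3-fold lower number from compound 2 to compound 4 (0.73 log units; beyond the scatter) as well. Both of these wider steps start from a limit of the assay, not from a number.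

Nothing measured here explains why the change from 4-methylpiperazin-1-yl to methyl lowers the number. Among these compounds, with only one readable pair at this carbonyl carbon, it remains open whether an ethyl group, a longer chain or a simple amine there would fall closer to methyl or to 4-methylpiperazin-1-yl.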